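Benzyloxy in place of amino: compound 2 to compound 3

This account rests on a few compounds, and the source may have more. Where it says the series, first, only, none or still open, it means among the compounds named here.

The series is read in a functional assay on Malme-3M cells (Homo sapiens) for cytotoxicity, read by MTT assay, with a stated time of 6 days (a higher number here means that more compound is needed for the effect, a lower number that less compound is needed), and so far gives no number. Compound 1 `COC(=O)c1c(-c2ccc(OC)cc2)oc2ccccc2c1=O` gives > 25 ug/mL and this is a limit, not a number. Compound 2 `COC(=O)c1c(-c2ccc(N)cc2)oc2ccccc2c1=O` gives > 25 ug/mL and this too is a limit, so compound 2 has no exact position on the scale.

Within the data shown here, on the shared core, compound 3 `COC(=O)c1c(-c2ccc(OCc3ccccc3)cc2)oc2ccccc2c1=O` carries benzyloxy in place of amino on an aromatic carbon, para to a large group benzyloxy in place of amino on an aromatic carbon (the only structural change from compound 2).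

Among the measured compounds shown here, one measured step bears on this place, namely a step that the two limits leave unreadable from compound 1 to compound 2 and it gives no size to carry over. The measured record is the limit of > 25 ug/mL in this assay, at which 2 of the 2 values shown sit, and it offers no direction either. No step beyond the usual scatter can therefore be argued for, and the expectation is that compound 3 also stays at the limit.

The expected step is a step that the limit leaves unreadable from compound 2 to compound 3 and it remains an estimate resting on limits alone. For compound 3 the estimated value is 30 ug/mL with an expected range from 12 ug/mL to 80 ug/mL and a report of a limit only is the likeliest outcome.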

Compound 3, concentration for half-maximal effect: > 25 ug/mL
Compound 3: no number, only a limit (the forecaster's own chance of this, stated with the estimate: 75%); the middle value does not contradict the limit.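

In this assay compound 3 gives > 25 ug/mL, which is a limit and not a number. Among these compounds, no step among compound 1, compound 2 and compound 3 can be read, as all of them stand at the same limit: the limit of > 25 ug/mL in this assay, at which 3 of the 3 values shown sit. The compounds shown leave open whether any change on the shared core gives a measurable value in this assay.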